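Bromo to methylsulfonyl on the aromatic ring of compound 2

The compounds below may be only part of what the source reports. "The series", "measured", "known", "first", "only" and "open" are said of these compounds alone.

Measured so far in an assay on isolated protein for inhibition of prostaglandin E2 receptor EP1 subtype (Homo sapiens); a lower number here means a stronger inhibitor, a higher number a weaker inhibitor:
compound 1 `O=C(O)c1cccc(C2=C(c3cc(Br)ccc3OCc3ccc(Cl)cc3)CCC2)c1` — 12.6 nM
compound 2 `O=C(O)c1cccc(C2=C(c3cc(Br)ccc3OCc3ccccc3)CCC2)c1` — 12.6 nM

Going by the values given here, compound 2 stands level with compound 1 within the usual scatter; the only measured step, no change at the digits printed from compound 1 to compound 2 (within the scatter), concerns the chloro on the benzyloxy side of the molecule and shows that this position tolerates removal of a halogen without effect.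

Compound 3 `CS(=O)(=O)c1ccc(OCc2ccccc2)c(C2=C(c3cccc(C(=O)O)c3)CCC2)c1` differs from compound 2 by methylsulfonyl in place of bromo on an aromatic carbon. Among the compounds with values here, no measured step touches this position or this kind of exchange, so the step from compound 1 to compound 2 gives no direct guide to its direction or size. The exchange swaps one heavy atom for four and brings in two hydrogen-bond acceptors where the core had none, which makes a change beyond the scatter in either direction possible.

For compound 3 the expected outcome is 30 nM, within 6 nM to 250 nM, which amounts to an expected step of a 2.4-fold higher number from compound 2 to compound 3 (0.38 log units; beyond the scatter) in this assay.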

Compound 3, half-maximal inhibitory concentration: 79.4 nM
For compound 3 the middle estimate is 2.6-fold (0.42 log units) below the measured one, within the range that was stated.
By their numbers in this assay, from the lowest: compounds 1 and 2 (each within the scatter of the next); then compound 3.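

In this assay the place para to a benzyloxy group responds to substitution: methylsulfonyl in place of bromo gives a 6.3-fold higher number from compound 2 to compound 3 (0.80 log units; beyond the scatter) and so a modest loss beyond the scatter. Going by these compounds alone, the earlier change at the chloro, no change at the digits printed from compound 1 to compound 2 (within the scatter), left the number where it was, so this is the first exchange to move it. Methylsulfonyl brings its greater heavy-atom count and its hydrogen-bond acceptors together, a single step cannot separate the two, and no measurement shown bears on the reason for the loss.

On these data alone, whether the loss is particular to methylsulfonyl or extends to other groups at this place remains open, for example a nitrile or a methoxy group. Also open, as far as these compounds go, is whether a chloro on the benzyloxy group would still leave the number unchanged with methylsulfonyl present.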